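Nucleoside series: thioether aryl swap at the core

The compounds below may be only part of what the source reports. "The series", "measured", "known", "first", "only" and "open" are said of these compounds alone.

Three compounds have numbers in an assay on isolated protein for binding affinity to Equilibrative nucleoside transporter 1 (Homo sapiens); on this read-out higher numbers stand for weaker inhibition and lower numbers for stronger inhibition. Compound 1 `O=[N+]([O-])c1cccc2c1CCN(c1ncnc3c1ncn3[C@@H]1O[C@H](CO)[C@@H](O)[C@H]1O)C2` gives 3020 nM in this assay. Compound 2 `Nc1ncnc2c1ncn2[C@@H]1O[C@H](COCCOCCNc2ncnc3c2ncn3[C@@H]2O[C@H](CO)[C@@H](O)[C@H]2O)[C@@H](O)[C@H]1O` gives 912000 nM. Compound 3 `Cc1cc(C)c(SCc2ncnc3c2ncn3[C@@H]2O[C@H](CO)[C@@H](O)[C@H]2O)c(C)c1` gives 33100 nM, the second highest of the three numbers; its gap to compound 1 and its gap to compound 2 both lie beyond the scatter, with compound 1 lower and compound 2 higher. Compound 4 `OC[C@H]1O[C@@H](n2cnc3c(CSc4ccc(Cl)c(Cl)c4)ncnc32)[C@H](O)[C@@H]1O` is not yet measured. It differs from compound 3 in one place: 3,4-dichlorophenyl in place of 2,4,6-trimethylphenyl on a sulfur. Going by the values given here, no measured pair shows this change, so the direction is open; a step of no more than the usual scatter is expected here. Compound 4 is accordingly estimated at 25000 nM, within 8000 nM to 100000 nM. The step from compound 3 to compound 4 is expected to be a 1.3-fold lower number from compound 3 to compound 4 (0.12 log units; within the scatter).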

Compound 4, half-maximal inhibitory concentration: 224 nM
Beside the measured number, compound 4's estimate is 110-fold (2.05 log units) above it, and the stated range ends above it.
By their numbers in this assay, from the lowest: compound 4; then compound 1; then compound 3; then compound 2.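

On this assay the aryl group on the sulfur proves to be a sensitive position: 3,4-dichlorophenyl in place of 2,4,6-trimethylphenyl gives a 150-fold lower number from compound 3 to compound 4 (2.17 log units; beyond the scatter) with the rest of the structure unchanged. Going by these compounds alone, this is the first single-place step, and it is large and toward stronger inhibition. Nothing available explains the size of this step.

Still open, from the compounds shown here alone, is whether one chlorine would be enough, as with 4-chlorophenyl or 3-chlorophenyl on the same sulfur. Also open, going by these compounds, is how an aryl group carrying an amine or a carboxylic acid would read there.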